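Opening a Three-Carbon Ring on the Amide Nitrogen

The compounds below may be only part of what the source reports. "The series", "measured", "known", "first", "only" and "open" are said of these compounds alone.

Of the compounds shown here, three sharing one core have been tested in a functional assay on MCF7 cells (Homo sapiens) for inhibition, read by MTT assay, with a stated time of 48 h; a lower number here means a stronger inhibitor, a higher number a weaker inhibitor. Compound 1 `COc1ccc(/C=C/c2cc(OC)cc(OC)c2/C=C/C(=O)NC2CC2)cc1` gives 3940 nM and stands second highest of the three numbers. Its nearest neighbour is compound 2 `COc1ccc(/C=C/c2cc(OC)cc(OC)c2/C=C/C(=O)N2CCCC2)cc1`, which gives 4200 nM; the step of a 1.1-fold higher number from compound 1 to compound 2 (0.03 log units; within the scatter) shows that pyrrolidin-1-yl in place of cyclopropylamino on the carbonyl carbon changes little. Compound 3 `CCCCNC(=O)/C=C/c1c(/C=C/c2ccc(OC)cc2)cc(OC)cc1OC` gives 1330 nM, and the step of a 3.0-fold lower number from compound 1 to compound 3 (0.47 log units; beyond the scatter) shows that butyl in place of cyclopropyl on the amide-type nitrogen gives a modest gain; the step of a 3.2-fold lower number from compound 2 to compound 3 (0.50 log units; beyond the scatter) points the same way.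

Compound 4 `COc1ccc(/C=C/c2cc(OC)cc(OC)c2/C=C/C(=O)NC(C)C)cc1` differs from compound 1 by isopropyl in place of cyclopropyl on an amide-type nitrogen. Among the measured compounds shown here, no measured pair opens this ring directly, so the nearest guide is compound 3, whose gain a 3.0-fold lower number from compound 1 to compound 3 (0.47 log units; beyond the scatter) came from a larger acyclic group on the same nitrogen. Isopropyl keeps the carbon count of cyclopropyl, so he expects a step of a 1.4-fold lower number from compound 1 to compound 4 (0.15 log units; within the scatter) that is small and directed toward a lower number, likely within or only just beyond the scatter. Compound 4 is therefore estimated at 2800 nM, with a range from 1300 nM to 6000 nM.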

Compound 4, half-maximal inhibitory concentration: 2560 nM
Beside the measured number, compound 4's estimate is 1.1-fold (0.04 log units) above it; the range from low to high includes it.
By their numbers in this assay, from the lowest: compounds 3, 4, 1 and 2 (each within the scatter of the next, the first and the last beyond it).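

In this assay, the step of a 1.5-fold lower number from compound 1 to compound 4 (0.19 log units; within the scatter) shows that cyclopropyl on this amide-type nitrogen can give way to isopropyl, losing the three-membered ring while keeping the three carbons, without the number leaving the scatter. The earlier compounds shown here separated butyl from cyclopropyl and from the pyrrolidin-1-yl amide, but the isopropyl amide joins neither side: the steps of a 1.9-fold higher number from compound 3 to compound 4 (0.28 log units; within the scatter) and a 1.6-fold lower number from compound 2 to compound 4 (0.22 log units; within the scatter) both stay within the scatter, even though the two ends of this series lie beyond it, so this one result places the isopropyl group in the gap without resolving it. Nothing available here bears on why the numbers fall as they do.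

As far as these compounds go, whether the modest gain seen with butyl extends to a longer chain such as hexyl, or holds for a more branched group such as tert-butyl, remains open. So does the outcome of placing a chain that ends in a hydroxyl group or an amine on the same nitrogen.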